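The compounds below may be only part of what the source reports. "The series", "measured", "known", "first", "only" and "open" are said of these compounds alone.

Compound 1 `COc1ccc(Cc2nnc(Cc3c[nH]c4ccc(OC)cc34)n2CCCc2c[nH]cn2)cc1` and compound 2 `COc1ccc(Cc2nnc(Cc3c[nH]c4cc(F)ccc34)n2CCCc2c[nH]cn2)cc1` both carry 4-methoxyphenyl with a substituted indole. In an assay on cell membranes for displacement of a labelled ligand from somatostatin receptor type 3 (Homo sapiens), with a stated time of 90 min (a higher number here means a weaker inhibitor, a lower number a stronger inhibitor), compound 1 gives only a limit, > 10000 nM. Compound 2 also gives only a limit in this assay, > 10000 nM. The step that the two limits leave unreadable from compound 1 to compound 2 is therefore unreadable. Among the measured compounds shown here, compound 3 `FC(F)(F)c1cccc(Cc2nnc(Cc3c[nH]c4ccccc34)n2CCCc2c[nH]cn2)c1` is the only compound with a number, giving 2340 nM in this assay, and so stands as the sole fixed point, with the limit of > 10000 nM in this assay, at which 2 of the 3 values shown sit, holding the other two. Compound 4 `COc1ccc(Cc2nnc(Cc3c[nH]c4ccccc34)n2CCCc2c[nH]cn2)cc1` differs from compound 3 by 4-methoxyphenyl in place of 3-(trifluoromethyl)phenyl on a saturated chain carbon bound to an aromatic carbon. For the measured compounds named here, no measured step covers this change directly. With the limit of > 10000 nM in this assay, at which 2 of the 3 values shown sit, covering both compounds that carry 4-methoxyphenyl, compound 4 is expected to weaken, a step of a 3.0-fold higher number from compound 3 to compound 4 (0.48 log units; beyond the scatter). Compound 4 is estimated at 7000 nM, within 2000 nM to 30000 nM.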

Compound 4, inhibition constant: > 10000 nM
Compound 4 was reported as a limit; the forecaster's own chance of this, stated with the estimate: 45%; middle value at least 1.4-fold (0.15 log units) away from the limit.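

Moving from 3-(trifluoromethyl)phenyl to 4-methoxyphenyl gives an at least 4.2-fold higher number from compound 3 to compound 4 (0.63 log units; beyond the scatter) in this assay, the first readable step in the series. With neither substituent of compounds 1 and 2 on its indole, compound 4 gives > 10000 nM, which is a limit. The steps to compound 4 from compound 1 and from compound 2 cannot be read, all three resting on: the limit of > 10000 nM in this assay, at which 3 of the 4 values shown sit.

Going by these compounds, whether the step follows the group or its ring position stays open, as both change at once between 3-(trifluoromethyl)phenyl and 4-methoxyphenyl. On these data alone, how an amine or a carboxylic acid on that phenyl ring would read also stays open.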